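The source may hold more compounds than are shown below. What is called first, only, known or untested is meant among the compounds shown, and "the series" means these compounds.

Measured compounds:
Compound 1 `Cc1ccc(CSc2ncnc3c2ncn3[C@@H]2O[C@H](CO)[C@@H](O)[C@H]2O)cc1`: 457 nM
Compound 2 `Nc1nc(SCc2cccc(Br)c2)c2ncn([C@@H]3O[C@H](CO)[C@@H](O)[C@H]3O)c2n1`: 2880 nM

Both compounds were tested in an assay on isolated protein for binding affinity to Equilibrative nucleoside transporter 1 (Homo sapiens); a higher number here means a weaker inhibitor, a lower number a stronger inhibitor. In this assay compound 1 gives 457 nM, and compound 2 gives 2880 nM, the highest of the two numbers; the gap between them lies beyond the usual scatter of repeated measurements, so compound 2 is clearly the weaker of the pair.

Compound 3 `CCCCSc1nc(N)nc2c1ncn2[C@@H]1O[C@H](CO)[C@@H](O)[C@H]1O` has not yet been measured. It differs from compound 2 in one place: propyl in place of 3-bromophenyl on a saturated chain carbon bound to a sulfur. For the measured compounds named here, no step between two measured compounds covers a change of this kind, so nothing in the measured data shows directly how it plays out. Compound 2 already sits at the weak end of the two numbers, and a further move toward weaker binding is expected, a step of a 3.5-fold higher number from compound 2 to compound 3 (0.54 log units; beyond the scatter). Compound 3 is therefore expected to give about 10000 nM in this assay, with a likely range from 3000 nM to 40000 nM.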

Compound 3, half-maximal inhibitory concentration: 12000 nM
Beside the measured number, compound 3's estimate is 1.2-fold (0.08 log units) below it; the range from low to high includes it.
By their numbers in this assay, from the lowest: compound 1; then compound 2; then compound 3.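

Swapping the 3-bromobenzyl group on the sulfur for butyl in this assay gives a 4.2-fold higher number from compound 2 to compound 3 (0.62 log units; beyond the scatter) and so weakens binding by a modest step beyond the scatter. For the compounds shown here, this is the first pair that differs in only one place, so it shows directly that the group on the sulfur affects the measured number even with the rest of the molecule unchanged: here, the compound 2 form with its aromatic ring is the stronger inhibitor. No measurement shown here accounts for the step.

From the compounds shown here alone, it remains open whether a plain benzyl group would bind as well as the 3-bromobenzyl group, which would test whether the bromine is needed. A longer chain such as hexyl, or an amine at the end of the butyl chain, could show whether a ring is required at all.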